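The compounds below may be only part of what the source reports. "The series", "measured", "known", "first", "only" and "open" are said of these compounds alone.

Measured compounds in a functional assay on HepG2 cells (Homo sapiens) for inhibition, read by sulforhodamine B assay, with a stated time of 24 h; a lower number here means a stronger inhibitor, a higher number a weaker inhibitor:
compound 1 `CC(=O)Nc1c(C#N)c(-c2ccccc2)cn1-c1ccc(S(=O)(=O)Nc2nccs2)cc1` gives 4020 nM;
compound 2 `CC(=O)Nc1c(C#N)c(-c2ccccc2)cn1-c1ccc(S(=O)(=O)Nc2ccccn2)cc1` gives 3490 nM;
compound 3 `Cc1nc2c(c(-c3ccccc3)cn2-c2ccc(S(=O)(=O)Nc3nccs3)cc2)c(=O)[nH]1` gives 3390 nM.

Compounds 1 and 2 share one core, and compounds 3 and 4 share another; the difference between the two cores is not broken down here. Within the first pair the change is pyridin-2-yl in place of 1,3-thiazol-2-yl on a sulfonamide nitrogen, and it made a 1.2-fold lower number from compound 1 to compound 2 (0.06 log units; within the scatter). The three measured values lie within the scatter of one another, so no order among compounds 1, 2 and 3 can be read from them.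

Compound 4 `Cc1nc2c(c(-c3ccccc3)cn2-c2ccc(S(=O)(=O)Nc3ccccn3)cc2)c(=O)[nH]1` is not yet measured. It relates to compound 3 by the change (pyridin-2-yl in place of 1,3-thiazol-2-yl on a sulfonamide nitrogen), the same change as from compound 1 to compound 2, since the two place descriptions agree word for word. On the first core this change gave a 1.2-fold lower number from compound 1 to compound 2 (0.06 log units; within the scatter), a step within the scatter, and on that basis a step of similar size is expected on the second core.

Compound 4 is therefore expected to give 3000 nM in this assay, with a likely range from 1500 nM to 6000 nM. The expected step is a 1.1-fold lower number from compound 3 to compound 4 (0.05 log units; within the scatter), resting on a 1.2-fold lower number from compound 1 to compound 2 (0.06 log units; within the scatter) and on the value of compound 3, 3390 nM.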

Compound 4, half-maximal inhibitory concentration: 3150 nM
The estimate for compound 4 lay 1.1-fold (0.02 log units) below the measured number; the range from low to high includes it.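

In this assay, pyridin-2-yl in place of 1,3-thiazol-2-yl on a sulfonamide nitrogen gave a 1.1-fold lower number from compound 3 to compound 4 (0.03 log units; within the scatter). Set beside the same change on the core of compound 1, the two steps agree: the same change on two cores in this assay, a 1.2-fold lower number (0.06 log units; within the scatter) from compound 1 to compound 2 and a 1.1-fold lower number (0.03 log units; within the scatter) from compound 3 to compound 4, 1.1-fold (0.03 log units) apart, within the scatter of two such steps

So this change gave no step beyond the scatter on either of the two cores, and in that limited sense its outcome carried from one core to the other, but the agreement is between two steps too small to be told from repeated measurement, so it does not show that a step of real size would carry across cores, and two cores make no rule for the whole series. The compounds shown leave open whether a group of another kind on the sulfonamide nitrogen, such as an aliphatic amine or a carboxylic acid, would give a step beyond the scatter. They also leave open whether a group other than phenyl on either core would move the number, and whether the two cores would then still respond alike.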